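The source may hold more compounds than are shown below. What is called first, only, known or untested is meant among the compounds shown, and "the series" means these compounds.

Three compounds sharing one core, and differing in the group on a carbonyl carbon, have been tested in a functional assay on PC-3 cells (Homo sapiens) for inhibition, read by sulforhodamine B assay, with a stated time of 72 h; on this read-out lower numbers stand for stronger inhibition and higher numbers for weaker inhibition. Compound 1 `Nc1sc(-c2ccc(Cl)cc2)c(-c2ccc(Cl)cc2)c1C(=O)NC1CCCCC1` gives 7300 nM. Compound 2 `Nc1sc(-c2ccc(Cl)cc2)c(-c2ccc(Cl)cc2)c1C(=O)N1CCC(=O)CC1=O` gives 9230 nM, and a 1.3-fold higher number from compound 1 to compound 2 (0.10 log units; within the scatter) shows that these two cannot be told apart. Compound 3 `Nc1sc(-c2ccc(Cl)cc2)c(-c2ccc(Cl)cc2)c1C(=O)NCc1ccccc1` gives 31800 nM, the highest number of the three, which makes it the weakest inhibitor in this small set.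

Compound 4 `Nc1sc(-c2ccc(Cl)cc2)c(-c2ccc(Cl)cc2)c1C(=O)N1CCNCC1` keeps the core and changes one place relative to compound 3: piperazin-1-yl in place of benzylamino on a carbonyl carbon. The benzylamino group leaves and a non-aromatic ring takes its place, as in compound 1 and compound 2, which both carry such a ring there.

For the measured compounds named here, two measured steps bear on this: a 4.4-fold higher number from compound 1 to compound 3 (0.64 log units; beyond the scatter) and a 3.4-fold higher number from compound 2 to compound 3 (0.54 log units; beyond the scatter). From the compounds shown here alone, both are modest, so a modest fall in the number is expected in this assay, although piperazin-1-yl itself is untested. The expected change is a 2.7-fold lower number from compound 3 to compound 4 (0.42 log units; beyond the scatter). For compound 4 the estimated value is 12000 nM, with an expected range of 4500 nM to 32000 nM.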

Compound 4, half-maximal inhibitory concentration: 2710 nM
The estimate for compound 4 lay 4.4-fold (0.65 log units) above the measured number; measured number below the stated range.
By their numbers in this assay, from the lowest: compound 4; then compounds 1 and 2 (each within the scatter of the next); then compound 3.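

In this assay, for the compounds shown here, the group on the carbonyl carbon turns out to have a wider effect than the earlier compounds showed: a 12-fold lower number from compound 3 to compound 4 (1.07 log units; beyond the scatter) is a large step, and it makes compound 4 the strongest inhibitor of the four. Piperazin-1-yl also stands apart from the other two non-aromatic rings, with a 3.4-fold lower number from compound 2 to compound 4 (0.53 log units; beyond the scatter) and a 2.7-fold lower number from compound 1 to compound 4 (0.43 log units; beyond the scatter) as the two modest steps. Replacing benzylamino with just any non-aromatic ring therefore does not give the full gain, and the identity of the ring matters at this position.

No measurement shown explains why piperazin-1-yl gives the lowest number. A morpholin-4-yl group, with an oxygen in place of the second ring nitrogen of piperazin-1-yl, would test whether that nitrogen matters.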